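The source may report more compounds than this note shows. Statements on the series, on what has been measured and on what is new or still open speak of the compounds shown alone.

Compound 1 `O=C(Nc1ccc2[nH]ccc2n1)[C@H]1CCCN1C(=O)C1(c2cccc(Cl)c2)CCCC1` gives 0.159 nM in an assay on isolated protein for inhibition of histone acetyltransferase p300 (Homo sapiens), with a stated time of 60 min; a higher number here means a weaker inhibitor, a lower number a stronger inhibitor. Compound 2 `O=C(Nc1ccc2[nH]ncc2n1)[C@H]1CCCN1C(=O)C1(c2ccc(F)cc2)CCC1` gives 0.126 nM in this assay. Compound 3 `COc1ccc(C2(C(=O)N3CCC[C@@H]3C(=O)Nc3ccc4[nH]ncc4n3)CCC2)cc1` gives 0.251 nM in this assay.

Compound 3 carries the highest of the three numbers, but this says little: its gap to compound 1 is within the scatter, and its gap to compound 2 is also within the scatter, so the three compounds sit in one narrow band. Among the compounds with values here, the only single-point change among the measured compounds at the six-membered aromatic ring of carbon only is a 2.0-fold higher number from compound 2 to compound 3 (0.30 log units; within the scatter), a step that stays within the scatter.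

Compound 4 `N#Cc1ccc(C2(C(=O)N3CCC[C@@H]3C(=O)Nc3ccc4[nH]ncc4n3)CCC2)cc1` differs from compound 3 at one place: cyano in place of methoxy on an aromatic carbon. Within the data shown here, the step from compound 2 to compound 3 is the only measured step that bears on it, since it exchanges a group at the same aromatic carbon, and it showed no movement beyond the scatter. Among the measured compounds shown here, no measured compound carries a cyano, so nothing in the set speaks for or against that group in particular. The expectation in this assay is therefore a step of no more than the scatter in either direction, and the estimate is a change of a 1.0-fold lower number from compound 3 to compound 4 (0.00 log units; within the scatter). Compound 4 is expected to give about 0.25 nM, with a range from 0.1 nM to 0.65 nM.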

Compound 4, half-maximal inhibitory concentration in the histone acetyltransferase p300 assay: 0.251 nM
For compound 4 the middle estimate is 1.0-fold (0.00 log units) below the measured one; the measured number falls inside the stated range.
By their numbers in the histone acetyltransferase p300 assay, from the lowest: compounds 2, 1, 3 and 4 (each within the scatter of the next).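

In the histone acetyltransferase p300 assay, cyano in place of methoxy on this aromatic carbon shows no change at the digits printed from compound 3 to compound 4 (within the scatter), and cyano in place of fluoro shows a 2.0-fold higher number from compound 2 to compound 4 (0.30 log units; within the scatter), so fluoro, methoxy and cyano at this place all stay within the scatter of one another. The same exchange is not silent on every read-out: a physicochemical assay for lipophilicity, at pH 7.4 (on this read-out lower numbers stand for lower lipophilicity and higher numbers for higher lipophilicity), shows a number 0.50 log units lower from compound 3 to compound 4 (beyond the scatter). In the physicochemical assay compound 3 gives 3.9 and compound 4 gives 3.4 on this read-out. For this one pair, going from 4-methoxyphenyl to 4-cyanophenyl lowers lipophilicity while the number in the histone acetyltransferase p300 assay holds: the measured distribution coefficient of compound 3, 3.9, and of compound 4, 3.4, a number 0.50 log units lower (beyond the scatter)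

Whether any group at this place can move the number in the histone acetyltransferase p300 assay beyond the scatter stays open, since an amine, a carboxylic acid or a longer chain on this aromatic carbon does not appear among the compounds shown. Also open, on these data alone, is whether the drop in the physicochemical assay seen for this pair would carry over to other groups at this place or to a different substituted core.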